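Ether substituent on the shared core: cyclopentyl to 3-phenylpropyl

The source may hold more compounds than are shown below. What is called first, only, known or untested is meant among the compounds shown, and "the series" means these compounds.

Working notes on two measured compounds and one awaiting measurement. Compound 1 `CCCCCOc1cc(CCc2nc(C)c(CC)s2)nc(NCc2cc(Cl)cc(NC(=O)OC(C)C)c2)c1` carries a pentyl group on the ring oxygen; in an assay on cells for binding affinity to Neuropeptide Y receptor type 1 (Homo sapiens) (a higher number here means a weaker inhibitor, a lower number a stronger inhibitor), compound 1 gives 35 nM. Compound 2 `CCc1sc(CCc2cc(OC3CCCC3)cc(NCc3cc(Cl)cc(NC(=O)OC(C)C)c3)n2)nc1C` carries a cyclopentyl group at the same oxygen, and in this assay compound 2 gives 11 nM, the lower of the two numbers; the change is a 3.2-fold lower number from compound 1 to compound 2 (0.50 log units; beyond the scatter).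

Compound 3 `CCc1sc(CCc2cc(OCCCc3ccccc3)cc(NCc3cc(Cl)cc(NC(=O)OC(C)C)c3)n2)nc1C` is the next member. It differs from compound 2 in one place: 3-phenylpropyl in place of cyclopentyl on an oxygen on an aromatic ring. For the measured compounds named here, the only measured step that bears on this position is a 3.2-fold lower number from compound 1 to compound 2 (0.50 log units; beyond the scatter), which moved from an open chain to a five-membered ring at the oxygen. Going by the values given here, the step to compound 3 goes the other way, back to an open three-carbon chain, but one ending in an aromatic ring, which neither measured compound shows; there is no measured step for a chain of this kind. On that basis the step from compound 2 to compound 3 is expected to be small, within the scatter or a modest rise toward the number of compound 1, giving a 2.3-fold higher number from compound 2 to compound 3 (0.36 log units; beyond the scatter). Compound 3 is therefore expected to give about 25 nM, with a range from 8 nM to 80 nM.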

Compound 3, half-maximal inhibitory concentration: 20 nM
Beside the measured number, compound 3's estimate is 1.3-fold (0.10 log units) above it, and the stated range covers the measured number.
By their numbers in this assay, from the lowest: compounds 2, 3 and 1 (each within the scatter of the next, the first and the last beyond it).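

In this assay the oxygen on an aromatic ring accepts a group ending in a phenyl ring, with 9 heavy atoms against 5 for cyclopentyl, and the reading barely separates: there is a 1.8-fold higher number from compound 2 to compound 3 (0.26 log units; within the scatter) and, on the open-chain side, a 1.8-fold lower number from compound 1 to compound 3 (0.24 log units; within the scatter) for the phenyl in place of ethyl. For the compounds shown here, compound 3 thus lies within the scatter of both neighbours, although those two stand apart beyond it, with a 3.2-fold lower number from compound 1 to compound 2 (0.50 log units; beyond the scatter) as the only step of that size at this position, so the series does not support a simple reading of ring against open chain at this oxygen. Nothing in the available data explains why these three groups give such close numbers.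

Still open, on these data alone, is how this assay would respond to an amine or a carboxylic acid at the end of the three-carbon chain in place of the phenyl ring. Also open, as far as these compounds go, is whether a benzyl group, a longer chain ending in phenyl, or a cyclohexyl group on the same oxygen would stay within the scatter of compound 2 and compound 3.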